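Swapping the Anilino Group for Hydroxy: What to Expect

The source may report more compounds than this note shows. Statements on the series, on what has been measured and on what is new or still open speak of the compounds shown alone.

Measured so far in a functional assay, read by spectrophotometry, with a stated time of 3 min; on this read-out higher numbers stand for weaker inhibition and lower numbers for stronger inhibition:
Compound 1 `O=c1cc(/C=N\O)c2c(OCc3ccccc3)cc(OCc3ccccc3)cc2o1` gives 38700 nM.
Compound 2 `O=c1cc(/C=N\Nc2ccc([N+](=O)[O-])cc2)c2ccc(OCc3ccccc3)cc2o1` gives 9510 nM.
Compound 3 `O=c1cc(/C=N\Nc2ccccc2)c2ccc(OCc3ccccc3)cc2o1` gives 13200 nM.

Within the data shown here, compound 3 holds the second highest number of the three; the one single-place step recorded, a 1.4-fold higher number from compound 2 to compound 3 (0.14 log units; within the scatter), sits within the scatter, so compounds 2 and 3 cannot be ordered. Compound 4 `O=c1cc(/C=N\O)c2ccc(OCc3ccccc3)cc2o1` differs from compound 3 by hydroxy in place of anilino on a double-bonded nitrogen. Among the measured compounds shown here, no measured step covers this exact change. Compound 1 also carries hydroxy on the double-bonded nitrogen, though it differs from compound 4 in a second benzyloxy group as well, and it gives a higher number than compound 3. A weakening step is therefore expected, roughly a 2.3-fold higher number from compound 3 to compound 4 (0.36 log units; beyond the scatter), because compound 1 gives 38700 nM. Compound 4 is estimated at 30000 nM, with a range from 10000 nM to 90000 nM.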

Compound 4, half-maximal inhibitory concentration: 22800 nM
Compound 4: middle estimate off by 1.3-fold (0.12 log units), on the high side, within the range that was stated.
By their numbers in this assay, from the lowest: compounds 2, 3, 4 and 1 (each within the scatter of the next, the first and the last beyond it).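

Putting hydroxy in place of anilino on the double-bonded nitrogen, a 1.7-fold higher number from compound 3 to compound 4 (0.24 log units; within the scatter), stays within the scatter, so in this assay the loss of the whole aromatic ring of anilino cannot be told from no change at all. Only the swap from (4-nitrophenyl)amino separates from the scatter, as a modest step: a 2.4-fold higher number from compound 2 to compound 4 (0.38 log units; beyond the scatter). Hydrogen in place of benzyloxy on an aromatic carbon, a 1.7-fold lower number from compound 1 to compound 4 (0.23 log units; within the scatter), also stays within the scatter. From the compounds shown here alone, how a methyl, a methoxy or a simple amine would read on that nitrogen stays open. No measurement shown accounts for any of these steps.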